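Series notes: diacid analogue of compound 2

The source may hold more compounds than are shown below. What is called first, only, known or untested is meant among the compounds shown, and "the series" means these compounds.

Compound 2 `CC[C@H](C)[C@H](NC(=O)CN(c1nc(Cl)nc2[nH]cnc12)C1CC1)C(=O)O` gives the lowest of the three numbers in a functional assay on the whole organism (Tail, strain ICR) with Mus musculus as the target, in the tail flick test, with a stated time of 150 min, at a dose of 25 umol/kg by the oral route (a lower number here means a weaker effect, a higher number a stronger effect of the compound at the dose given), at 6.71%; compound 1 `CC(C)[C@H](NC(=O)CN(c1nc(Cl)nc2[nH]cnc12)C1CC1)C(=O)OCc1ccccc1` gives 17.9% and compound 3 `O=C(CN(c1nc(Cl)nc2[nH]cnc12)C1CC1)N[C@@H](CCC(=O)OCc1ccccc1)C(=O)OCc1ccccc1` gives 44.5%. Compound 4 `O=C(O)CC[C@H](NC(=O)CN(c1nc(Cl)nc2[nH]cnc12)C1CC1)C(=O)O` differs from compound 2 by 2-carboxyethyl in place of sec-butyl on a saturated chain carbon bound to an amide-type nitrogen and a carbonyl carbon. For the measured compounds named here, the one measured step that bears on this change is a number 26.6 percentage points higher from compound 1 to compound 3 (beyond the scatter), where a branched alkyl group at the same place gave way to a longer chain carrying a carbonyl. Carried over to compound 2, a step of similar direction but uncertain size is expected, since compound 2 already stands lowest and no measured pair shows the free acid at this place. For compound 4 a gain of a number 13.3 percentage points higher from compound 2 to compound 4 (beyond the scatter) is estimated, giving an expected 20% within 4% to 42%.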

Compound 4, a percentage reported as activity, at one dose (the size of the read-out at that dose, not a potency): 29.5%
Compound 4: the middle estimate sits 9.5 percentage points below what was measured; low and high end bracket the measured number.
By their numbers in this assay, from the lowest: compound 2; then compound 1; then compound 4; then compound 3.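

In this assay, the step to 2-carboxyethyl in place of sec-butyl on this saturated chain carbon is a number 22.8 percentage points higher from compound 2 to compound 4 (beyond the scatter). The earlier rise at this place came from a pair of benzyl esters, whereas this pair carries a free carboxylic acid on the same carbon, so the rise is not confined to the esters. No available data account for this rise.

The compounds shown leave open whether a shorter carboxymethyl chain or a chain ending in an amine at this place would move the number in the same direction.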